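Trifluoromethyl for fluoro on a cyclic phosphorus nucleoside core

This account rests on a few compounds, and the source may have more. Where it says the series, first, only, none or still open, it means among the compounds named here.

Measured compounds:
- compound 1, `O=c1[nH]c(=O)n([C@H]2C[C@@H]3O[PH](O)(O)OC[C@H]3O2)cc1F`, 19 ug/mL
- compound 2, `COP1(=O)OC[C@H]2O[C@@H](n3cc(Br)c(=O)[nH]c3=O)C[C@@H]2O1`, > 100 ug/mL
- compound 3, `O=c1[nH]c(=O)n([C@H]2C[C@H](O)[C@@H](COP(=O)(O)O)O2)cc1C(F)(F)F`, 212 ug/mL

In a functional assay on Raji cells (Homo sapiens) for antiproliferative activity (a lower number here means a stronger inhibitor, a higher number a weaker inhibitor), compound 1 gives 19 ug/mL, the lowest of the two numbers reported. Compound 3 carries a trifluoromethyl and an open phosphate rather than the cyclic phosphorus part of compound 1. In this assay compound 3 gives 212 ug/mL, a higher number, and its gap to compound 1 lies beyond the scatter. For compound 2 this assay reports only a limit, > 100 ug/mL, and no number.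

Compound 4, `O=c1[nH]c(=O)n([C@H]2C[C@@H]3O[PH](O)(O)OC[C@H]3O2)cc1C(F)(F)F`, keeps the core of compound 1 and changes one place: trifluoromethyl in place of fluoro on an aromatic carbon. Among the measured compounds shown here, no measured pair differs in this change alone, so its size is not known from these data. Compound 3 shows that a trifluoromethyl compound can reach a high number, but it also differs in the phosphorus part, so that comparison is not clean. Compound 4 is therefore expected to sit somewhat weaker than compound 1, with a step of a 3.2-fold higher number from compound 1 to compound 4 (0.50 log units; beyond the scatter) estimated in this assay. The estimate for compound 4 is 60 ug/mL, within a range from 15 ug/mL to 250 ug/mL.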

Compound 4, concentration for 50% inhibition: >= 500 ug/mL
Compound 4: a limit, no number (the forecaster's own chance of this, stated with the estimate: 20%); at least 8.3-fold (0.92 log units) between middle value and limit.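

With the core of compound 1 held fixed, the change from fluoro to trifluoromethyl on this aromatic carbon can now be read on its own in this assay, and it gives an at least 26-fold higher number from compound 1 to compound 4 (1.42 log units; beyond the scatter). The reading for compound 4 is a limit and not a number, so this step marks only how large the loss is known to be so far: the limit of >= 500 ug/mL in this assay, at which 1 of the 4 values shown sits. Compound 3 could not show this, as its phosphorus part also differs from that of compound 1, whereas compound 4 shows that trifluoromethyl at this place costs a large loss on the cyclic phosphorus core.

From the compounds shown here alone, what stays open is whether any group other than fluoro at this place brings such a loss on this core. A methyl, a nitrile or an amine on the same aromatic carbon would begin to answer that.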